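The compounds below may be only part of what the source reports. "The series", "measured", "known", "first", "only" and "open" are said of these compounds alone.

Measured so far in an ADME assay on microsomes from liver (Mus musculus) for metabolic stability, read by LC-MS, using NADPH, with a stated time of 60 min, tested at 1 uM; a lower number here means that the compound disappears faster, a higher number that the compound lasts longer
compound 1 `O=S(=O)(c1cccc(C(F)(F)F)c1)N1CCc2ccc(OCc3c(F)cccc3Cl)cc21` gives 0.0483 h
compound 2 `O=C(O)CCCC1Cc2ccc(-c3cc(F)cc(OC(F)F)c3)cc2N1S(=O)(=O)c1cccc(C(F)(F)F)c1` gives 1.56 h
compound 3 `O=C(O)CCCC1CN(S(=O)(=O)c2cccc(C(F)(F)F)c2)c2cc(-c3cc(F)cc(OC(F)F)c3)ccc21` gives 0.57 h

Among these three, compound 2 stands highest, with a half-life of 1.56 h. Compound 3 and compound 1 both lie lower, each by more than the usual scatter of repeat measurements.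

The next molecule, compound 4 `O=C(CC1Cc2ccc(-c3cc(F)cc(OC(F)F)c3)cc2N1S(=O)(=O)c1cccc(C(F)(F)F)c1)N1CCS(=O)(=O)CC1`, has not yet been measured. It differs from compound 2 as follows: (1,1-dioxothiomorpholin-4-yl)carbonyl in place of 2-carboxyethyl on a saturated chain carbon bound to a saturated ring carbon. In words, (1,1-dioxothiomorpholin-4-yl)carbonyl stands in place of 2-carboxyethyl on a saturated chain carbon bound to a saturated ring carbon.

Within the data shown here, no measured pair shows this change alone, so any forecast in this assay rests on thin evidence. Among the measured compounds shown here, the one hint is compound 1, the only measured compound without the 2-carboxyethyl group, which gives 0.0483 h, although it also differs from compound 2 elsewhere. A downward move of moderate size, probably beyond the scatter, therefore seems likely. The expected change is a 2.6-fold lower number from compound 2 to compound 4 (0.41 log units; beyond the scatter). The estimated half-life of compound 4 is 0.6 h, within an expected range from 0.15 h to 2 h.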

Compound 4, half-life: 0.0333 h
Estimate against measurement, compound 4: 18-fold (1.26 log units) above, and the stated range ends above it.
By their numbers in this assay, from the lowest: compounds 4 and 1 (each within the scatter of the next); then compound 3; then compound 2.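

In this assay, putting (1,1-dioxothiomorpholin-4-yl)carbonyl in place of 2-carboxyethyl on a saturated chain carbon bound to a saturated ring carbon gives a 47-fold lower number from compound 2 to compound 4 (1.67 log units; beyond the scatter). Among these compounds, this is the first step measured at this place, and its size shows that the half-life depends strongly on what is attached there, even with the rest of the molecule unchanged. Nothing available here explains why the half-life falls so far.

The step changes several things at once: the carboxylic acid and its hydrogen-bond donor leave, while a larger group with a six-membered ring enters, so the compounds shown leave open which of these changes matters. A primary amide or a morpholine amide on the same chain would help to separate them.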